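Swapping the anilide for a pyrrolidine amide: cytotoxicity outlook

The compounds below may be only part of what the source reports. "The series", "measured", "known", "first", "only" and "open" are said of these compounds alone.

Compounds measured so far in an ADME assay on NCM460 cells (Homo sapiens) for cytotoxicity, read by MTT assay, with a stated time of 72 h; a higher number here means a weaker inhibitor, a lower number a stronger inhibitor:
Compound 1 `CCc1cccc(NC(=O)c2cccc(/C=C3\CC(=O)N(Cc4ccccc4)C3=O)c2)c1` gives only a limit of the assay, > 100000 nM.
Compound 2 `CCCCCN1C(=O)C/C(=C\c2cccc(C(=O)NCCCC)c2)C1=O` gives only a limit of the assay, > 100000 nM.
Compound 3 `CCc1cccc(NC(=O)c2cccc(/C=C3\CC(=O)N(c4ccccc4)C3=O)c2)c1` gives only a limit of the assay, > 100000 nM.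

In this assay compound 3 therefore stands at a limit rather than at a number, and the two other values shown are limits as well, all at the limit of > 100000 nM in this assay, at which 3 of the 3 values shown sit. Because of that, the step that the two limits leave unreadable from compound 1 to compound 3 cannot be read. Compound 4 `O=C(c1cccc(/C=C2\CC(=O)N(c3ccccc3)C2=O)c1)N1CCCC1` differs from compound 3 by pyrrolidin-1-yl in place of (3-ethylphenyl)amino on a carbonyl carbon. Among the compounds with values here, no measured step concerns a change on that carbonyl carbon, so no direction is set by the data. Since every known value in this assay sits at the limit, compound 4 is expected to sit there too, with the expected step that the limit leaves unreadable from compound 3 to compound 4 being none beyond the scatter. The estimate for compound 4 in this assay is 150000 nM, between 60000 nM and 400000 nM.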

Compound 4, half-maximal inhibitory concentration: > 100000 nM
Compound 4: a limit, no number (the forecaster's own chance of this, stated with the estimate: 80%); the middle value is on the limit's open side.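

In this assay compound 3 and compound 4 both give only a limit of the assay, so the step between them cannot be read. The compounds shown leave open which change, if any, would give a readable number in this assay at all.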